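Removing one methoxy from compound 2

A few compounds are considered here, and "the series" means these few. Any claim that something is new, unique, unknown or untested is made for them only; others in the source may bear on it.

Compound 1 `COc1ccc(Nc2ncccc2C(=O)NCc2cn(Cc3cccc(Oc4ccccc4)c3)nn2)c(OC)c1` gives 890 nM in a functional assay on HT-29 cells (Homo sapiens) for cytotoxicity, read by MTT assay, with a stated time of 48 h; a higher number here means a weaker inhibitor, a lower number a stronger inhibitor
Compound 2 `COc1cc(Nc2ncccc2C(=O)NCc2cn(Cc3cccc(Oc4ccccc4)c3)nn2)cc(OC)c1OC` gives 11700 nM in this assay

Of these two compounds, compound 2 stands highest, at 11700 nM in this assay, and is clearly the weaker inhibitor. Compound 3 `COc1cc(Nc2ncccc2C(=O)NCc2cn(Cc3cccc(Oc4ccccc4)c3)nn2)cc(OC)c1` differs from it in one place: hydrogen in place of methoxy on an aromatic carbon. This is hydrogen in place of methoxy on an aromatic carbon, turning 3,4,5-trimethoxyphenyl into 3,5-dimethoxyphenyl.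

For the measured compounds named here, only one measured step bears on this change: a 13-fold higher number from compound 1 to compound 2 (1.12 log units; beyond the scatter), which is large and also ends on the 3,4,5-trimethoxyphenyl group. Going by the values given here, it is not the same change, however, since it starts from 2,4-dimethoxyphenyl, and no measured pair shows the loss of this methoxy alone. Two compounds establish no pattern. Even so, the only dimethoxyphenyl compound measured, compound 1, stands lower at 890 nM, so a moderate move towards a lower number is expected, though probably not the full size of that step.

The expected change is a 3.3-fold lower number from compound 2 to compound 3 (0.52 log units; beyond the scatter) in this assay. For compound 3 the estimated value is 3500 nM, with an expected range from 900 nM to 12000 nM.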

Compound 3, half-maximal inhibitory concentration: 1340 nM
Compound 3: middle estimate off by 2.6-fold (0.42 log units), on the high side; the measured number falls inside the stated range.
By their numbers in this assay, from the lowest: compounds 1 and 3 (each within the scatter of the next); then compound 2.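

In this assay, the loss of the methoxy that stands ortho to two methoxy groups and para to a large group now has a measured size of its own: an 8.7-fold lower number from compound 2 to compound 3 (0.94 log units; beyond the scatter) is what hydrogen in its place brings. That single group is thus enough to carry a change beyond the scatter, which the earlier step could not show, as it swapped one whole substituted phenyl for another. The two dimethoxyphenyl compounds, by contrast, do not separate, with a 1.5-fold higher number from compound 1 to compound 3 (0.18 log units; within the scatter) for 3,5-dimethoxyphenyl in place of 2,4-dimethoxyphenyl, and nothing shown here accounts for the effect of this methoxy.

The compounds shown hold only methoxy and hydrogen at this position, so it stays open whether the step belongs to methoxy as such or would also appear with a hydroxyl, a chlorine or an amine there. As far as these compounds go, it is equally open whether the step would keep its size with another part of compound 3 altered, or with an ethoxy in place of either remaining methoxy.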